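The source may hold more compounds than are shown below. What is called first, only, known or untested is meant among the compounds shown, and "the series" means these compounds.

Measured so far in an ADME assay on MCF7-DOX cells (Homo sapiens) for cytotoxicity, read by MTT assay, with a stated time of 48 h; a higher number here means a weaker inhibitor, a lower number a stronger inhibitor:
- Compound 1 `COc1cc(OC)c(C(=O)/C=C/c2ccc(N3CCN(C(=O)OC(C)(C)C)CC3)cc2)c(O)c1CC=C(C)C`: > 100000 nM, a limit of the assay and not a number
- Compound 2 `COc1cc(OC)c(C(=O)/C=C/c2cccc([N+](=O)[O-])c2)c(O)c1CC=C(C)C`: 57000 nM
- Compound 3 `COc1cc(OC)c(C(=O)/C=C/c2ccc(Cl)cc2)c(O)c1CC=C(C)C`: 43400 nM

Compound 3 stands level with compound 2: a 1.3-fold lower number from compound 2 to compound 3 (0.12 log units; within the scatter). Going by the values given here, these two are the only true numbers so far.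

Next is compound 4 `COc1cc(OC)c(C(=O)/C=C/c2ccc(N3CCNCC3)cc2)c(O)c1CC=C(C)C`, which has piperazin-1-yl in place of chloro on an aromatic carbon, para to a large group: piperazin-1-yl in place of chloro on an aromatic carbon.

Two measurements bear on this change, and neither bears on it directly. Among the compounds with values here, the one step between numbers, a 1.3-fold lower number from compound 2 to compound 3 (0.12 log units; within the scatter), exchanges 3-nitrophenyl for 4-chlorophenyl and stays within the scatter, so it gives no size for a piperazin-1-yl change. Within the data shown here, compound 1 is the only measured compound with a piperazine ring. Compound 1 gives > 100000 nM, which is a limit. Among the measured compounds shown here, its ring also carries a tert-butyl carbamate that compound 4 lacks, so it fixes no size for this step either.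

As far as these compounds go, no step beyond the scatter is therefore expected, and the direction remains open. From the compounds shown here alone, the estimate starts from compound 3 at 43400 nM, with a wide range because the change itself is untested. The expected step is a 1.2-fold lower number from compound 3 to compound 4 (0.09 log units; within the scatter). For compound 4 the estimated value is 35000 nM, with an expected range of 9000 nM to 100000 nM.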

Compound 4, half-maximal inhibitory concentration: 57800 nM
Compound 4: the middle estimate sits 1.7-fold (0.22 log units) below what was measured, and the stated range covers the measured number.
By their numbers in this assay, from the lowest: compounds 3, 2 and 4 (each within the scatter of the next). At a limit, above all of these: compound 1.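

In this assay, exchanging chloro for piperazin-1-yl on the aromatic carbon para to a large group gives a 1.3-fold higher number from compound 3 to compound 4 (0.12 log units; within the scatter). Going by these compounds alone, this position therefore accepts a six-membered non-aromatic ring with a hydrogen-bond donor without a step beyond the scatter, and compound 4 supplies the first true number for a piperazine-bearing member of the series. Hydrogen in place of tert-butoxycarbonyl on the ring amine nitrogen gives an at least 1.7-fold lower number from compound 1 to compound 4 (0.23 log units; that floor lies within the scatter), which fixes only a floor for that change, and compound 1 stays a limit of the assay and not a number: the limit of > 100000 nM in this assay, at which 1 of the 4 values shown sits.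

The compounds shown leave open whether a morpholine ring, or a methyl group on the free nitrogen of the piperazine, would give a step beyond the scatter at this same carbon. Also open, as far as these compounds go, is whether a carboxylic acid or a primary amine placed here would separate from chloro and piperazin-1-yl, or would fall within the scatter as well.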